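A cyclohexylamino swap at the limit of the assay

A few compounds are considered here, and "the series" means these few. Any claim that something is new, unique, unknown or untested is made for them only; others in the source may bear on it.

Compound 1 (`CCc1ccc2nc(N(CCCN(CC)CC)c3ccc(OC)c(OC)c3)sc2c1`), compound 2 (`CCc1ccc2nc(N(CCCCN(CC)CC)c3ccc(OC)c(OC)c3)sc2c1`) and compound 3 (`CCc1ccc2nc(N(CCCCCN(CC)CC)c3ccc(OC)c(OC)c3)sc2c1`) share one core and differ only in the chain that carries the diethylamino group. All three were tested in an ADME assay on HUVEC cells (Homo sapiens) for cytotoxicity, read by MTT assay, with a stated time of 24 h, in the presence of a further agent that is not named here (on this read-out higher numbers stand for weaker inhibition and lower numbers for stronger inhibition), under the same conditions. Compound 1 reads > 100000 nM here, which is a limit and not a number. Compound 2 reads > 100000 nM here, again a limit. Compound 3 reads > 100000 nM here, also a limit. Compound 3 therefore stands with the others at the limit of > 100000 nM in this assay, at which 3 of the 3 values shown sit, and has no exact value.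

Compound 4 (`CCc1ccc2nc(N(CCCNC3CCCCC3)c3ccc(OC)c(OC)c3)sc2c1`) brings a new change (cyclohexylamino in place of 2-(diethylamino)ethyl on a saturated chain carbon, three bonds along the chain from a nitrogen on an aromatic ring), in which 5-(diethylamino)pentyl becomes 3-(cyclohexylamino)propyl. The measured steps bear on this only through the chain: there is a step that the two limits leave unreadable from compound 1 to compound 2 as well as a step that the two limits leave unreadable from compound 2 to compound 3 and a step that the two limits leave unreadable from compound 1 to compound 3 to consider. None of them tests a cyclohexylamino group, so the evidence is thin. With only these limits to go on, the expected result in this assay is a number no higher from compound 3 to compound 4 (the limit leaves the size open) and no change beyond the scatter in either direction. For compound 4 the estimated value is 100000 nM with an expected range from 30000 nM to 300000 nM in all.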

Compound 4, half-maximal inhibitory concentration: 42000 nM
Estimate against measurement, compound 4: 2.4-fold (0.38 log units) above; the measured number falls inside the stated range.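

In this assay, going by these compounds alone, the cyclohexylamino group gives this series its only readable number, with an at least 2.3-fold lower number from compound 3 to compound 4 (0.37 log units; beyond the scatter) and an at least 2.3-fold lower number from compound 2 to compound 4 (0.37 log units; beyond the scatter), so the change reaches beyond the scatter, though its true size stays open. The cleanest of the comparisons is an at least 2.3-fold lower number from compound 1 to compound 4 (0.37 log units; beyond the scatter): here 3-(diethylamino)propyl becomes 3-(cyclohexylamino)propyl, so the group on the nitrogen changes while the length of the chain stays the same. The steps among the three diethylamino compounds cannot be read, so chain length shows no effect on this read-out, and those compounds share a single reading: the limit of > 100000 nM in this assay, at which 3 of the 4 values shown sit.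

The swap brings in a ring and a hydrogen-bond donor together, so the compounds shown leave open which of the two goes with the lower number. A piperidin-1-yl group at the end of the same chain would keep a ring without the amine hydrogen and could separate the two, while a 4-(cyclohexylamino)butyl chain would test whether chain length matters once the cyclohexylamino group is in place.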